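The compounds below may be only part of what the source reports. "The series", "measured", "known", "first", "only" and "open" are said of these compounds alone.

Compounds that share one core were tested in a functional assay on MCF7 cells (Homo sapiens) for antiproliferative activity, read by CellTiter-Glo, with a stated time of 5 days; a lower number here means a stronger inhibitor, a higher number a weaker inhibitor. In this assay compound 1 `CC/C(=C(/c1ccc(/C=C/C(=O)O)cc1)c1ccc2c(cnn2C)c1)c1ccc(F)cc1Cl` gives 81 nM, and compound 3 `CC/C(=C(/c1ccc(/C=C/C(=O)O)cc1)c1ccc(-c2cscn2)cc1)c1ccccc1` gives 120 nM. These two numbers lie within the usual scatter of each other, so compound 3 cannot be ranked apart from compound 1. Compound 2 `CC/C(=C(/c1ccc(/C=C/C(=O)O)cc1)c1ccn2nccc2c1)c1ccccc1` gives > 500 nM, which is a limit of the assay and not a number.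

Compound 4 `CC/C(=C(/c1ccc(/C=C/C(=O)O)cc1)c1ccc(-c2cnsc2)cc1)c1ccccc1` has not yet been measured. It has the same atoms as compound 3, joined differently: 1,2-thiazol-4-yl in place of 1,3-thiazol-4-yl on an aromatic carbon. In words, 1,2-thiazol-4-yl stands in place of 1,3-thiazol-4-yl on an aromatic carbon. Among the compounds with values here, no two measured compounds here differ in only one place, so the data give no direct guide to the size of this change. The expectation therefore starts from compound 3 at 120 nM, and no step beyond the scatter is expected in either direction. The expected change is a 1.1-fold higher number from compound 3 to compound 4 (0.03 log units; within the scatter). Compound 4 is estimated at 130 nM, with an expected range of 50 nM to 350 nM.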

Compound 4, half-maximal inhibitory concentration: 120 nM
The estimate for compound 4 lay 1.1-fold (0.03 log units) above the measured number; the range from low to high includes it.
By their numbers in this assay, from the lowest: compounds 1, 3 and 4 (each within the scatter of the next). At a limit, above all of these: compound 2.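

Within the data shown here, putting 1,2-thiazol-4-yl in place of 1,3-thiazol-4-yl, on an aromatic carbon para to a large group, gives in this assay the first reading of a single change: no change at the digits printed from compound 3 to compound 4 (within the scatter). The earlier compounds shown here could not show this, since none of them differed in only one place; here, two rings with the same atoms joined differently cannot be told apart in this assay at this position. Nothing measured here explains why the two rings read alike.

Going by these compounds, how a smaller or quite different group, such as an amine or a methoxy group, would compare in the same place stays open. On these data alone, it is also open whether this exchange would read the same on a compound with the other groups of compound 1.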